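Naphthalen-1-yl in Place of Phenoxy: an Acidity Estimate

The source may report more compounds than this note shows. Statements on the series, on what has been measured and on what is new or still open speak of the compounds shown alone.

Compound 1 `c1ccc(Oc2ccc3c(NCCCNCc4ccco4)ccnc3c2)cc1`: 9.28
Compound 2 `COc1cccc(CNCCCNc2ccnc3cc(Cc4ccccc4)ccc23)c1O`: 9.47
Compound 3 `COc1cccc(CNCCCNc2ccnc3cc(Oc4ccccc4)ccc23)c1O`: 9.28

In a physicochemical assay for acid dissociation, compound 1 stands level with compound 3, the two together giving the lowest of the three numbers, and no change at the digits printed from compound 1 to compound 3 (within the scatter). Compound 2 gives the highest of the three values, though by a margin the scatter covers. Compound 4 `c1coc(CNCCCNc2ccnc3cc(-c4cccc5ccccc45)ccc23)c1` differs from compound 1 by naphthalen-1-yl in place of phenoxy on an aromatic carbon. Among the compounds with values here, the only measured step at that same aromatic carbon is a number 0.19 log units lower from compound 2 to compound 3 (within the scatter), so the numbers at hand give no sign that a group there shifts the acid dissociation constant beyond the scatter. For compound 4 a shift of a number 0.02 log units higher from compound 1 to compound 4 (within the scatter) is therefore expected, with an estimated value of 9.3, ranging from 8.9 to 9.7.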

Compound 4, acid dissociation constant: 9.47
Beside the measured number, compound 4's estimate is 0.17 log units below it; the measured number falls inside the stated range.
By their numbers in this assay, from the lowest: compounds 1, 3, 2 and 4 (each within the scatter of the next).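

In this assay naphthalen-1-yl in place of phenoxy gives a number 0.19 log units higher from compound 1 to compound 4 (within the scatter) and so extends the earlier picture at this aromatic carbon. Within the data shown here, until now the only step there was the exchange of benzyl for phenoxy, and a group of 10 heavy atoms with 2 aromatic rings of carbon only also stays within the scatter. No available evidence accounts for this reading. The compounds shown leave open whether an amine or a carboxylic acid at this carbon would move the number beyond the scatter. They also leave open whether naphthalen-1-yl gives the same result with 2-hydroxy-3-methoxyphenyl in place of furan-2-yl.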